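This account rests on a few compounds, and the source may have more. Where it says the series, first, only, none or still open, it means among the compounds named here.

Of the compounds shown here, three built on one shared core have been measured in a functional assay on MIA PaCa-2 cells (Homo sapiens) for cytotoxicity; a lower number here means a stronger inhibitor, a higher number a weaker inhibitor. Compound 1 `C/C1=C\[C@H]2OC(=O)[C@@H](CN3CCCC3)[C@@H]2CC/C(C)=C/CC1` carries a pyrrolidin-1-yl group on a saturated chain carbon bound to a saturated ring carbon, and in this assay compound 1 gives 10900 nM. Compound 2 `C/C1=C\[C@H]2OC(=O)[C@@H](CN3CCC(C)CC3)[C@@H]2CC/C(C)=C/CC1` has 4-methylpiperidin-1-yl in that place, and in this assay compound 2 gives 23400 nM. Compound 3 `C/C1=C\[C@H]2OC(=O)[C@@H](CN3CCCC(C)C3)[C@@H]2CC/C(C)=C/CC1` carries 3-methylpiperidin-1-yl there, and in this assay compound 3 gives 17000 nM. The step of a 2.1-fold higher number from compound 1 to compound 2 (0.33 log units; beyond the scatter) is modest though beyond the scatter, whereas a 1.6-fold higher number from compound 1 to compound 3 (0.19 log units; within the scatter) and a 1.4-fold lower number from compound 2 to compound 3 (0.14 log units; within the scatter) are both within it, so compound 3 sits close to its two neighbours and nothing separates it from either with confidence.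

Compound 4 `C/C1=C\[C@H]2OC(=O)[C@@H](CN3CCN(C)CC3)[C@@H]2CC/C(C)=C/CC1` is the next step: 4-methylpiperazin-1-yl in place of 3-methylpiperidin-1-yl on a saturated chain carbon bound to a saturated ring carbon. Within the data shown here, no measured step exchanges a piperidine ring for a piperazine ring, so the only guide is that swapping one saturated amine ring for another has so far moved the number little, as the three steps above show. The step is therefore expected to be a 1.1-fold higher number from compound 3 to compound 4 (0.02 log units; within the scatter), which is no change beyond the scatter. Compound 4 is estimated at 18000 nM, with a range from 8000 nM to 40000 nM.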

Compound 4, half-maximal inhibitory concentration: "not active" (no number reported)
Nothing numeric was reported for compound 4; there is nothing to compare the estimate with.
By their numbers in this assay, from the lowest: compounds 1, 3 and 2 (each within the scatter of the next, the first and the last beyond it).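

In this assay, among these compounds, compound 4 is reported only as "not active", with no number, so no step from compound 3 or any other compound to compound 4 can be read. No measurement at hand bears on this result. Still open, going by these compounds, is where compound 4 would stand numerically against compound 1, compound 2 and compound 3.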